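Thiophen-2-yl for phenyl on the imine carbon, two cores

The source may hold more compounds than are shown below. What is called first, only, known or untested is meant among the compounds shown, and "the series" means these compounds.

Two pairs are in view. Compound 1 `CN1CCN(c2ccc(Nc3ncc(/N=C/c4ccccc4)c(NC4CCCC4)n3)cc2)CC1` and compound 2 `CN1CCN(c2ccc(Nc3ncc(/N=C/c4cccs4)c(NC4CCCC4)n3)cc2)CC1` share one core; compound 3 `CC(C)Nc1nc(Nc2ccc(S(N)(=O)=O)cc2)ncc1/N=C/c1ccccc1` and compound 4 `CC(C)Nc1nc(Nc2ccc(S(N)(=O)=O)cc2)ncc1/N=C/c1cccs1` share another. The difference between the two cores is not broken down here.

In a functional assay on HeLa cells (Homo sapiens) for antiproliferative activity, read by MTT assay (on this read-out lower numbers stand for stronger inhibition and higher numbers for weaker inhibition), compound 1 gives only a limit, > 100000 nM. In this assay compound 2 gives 25700 nM. The change between the two is thiophen-2-yl in place of phenyl on a carbon with a double bond to nitrogen and the step it made is an at least 3.8-fold lower number from compound 1 to compound 2 (0.59 log units; beyond the scatter). The step is open at one end because the limit of > 100000 nM in this assay, at which 2 of the 3 values shown sit, is where compound 1 sits, so its full size is not known.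

In this assay compound 3 gives only a limit, > 100000 nM. Compound 4 differs from compound 3 by thiophen-2-yl in place of phenyl on a carbon with a double bond to nitrogen, which is the same change on a place described in the same words as in the first pair. Among the compounds with values here, the question is whether the move off the limit seen once repeats on the second core; only one earlier instance is available, so the expectation is loosely held.

The expected step is an at least 3.3-fold lower number from compound 3 to compound 4 (0.52 log units; beyond the scatter), which rests on an at least 3.8-fold lower number from compound 1 to compound 2 (0.59 log units; beyond the scatter). Compound 4 is accordingly expected to give about 30000 nM in this assay, with a plausible span from 8000 nM to 100000 nM, and a real chance that it too returns only a limit.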

Compound 4, half-maximal inhibitory concentration: > 100000 nM
Compound 4 gave a limit, no number; the forecaster's own chance of this, stated with the estimate: 40%; at least 3.3-fold (0.52 log units) between middle value and limit.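

In this assay compound 4 returns only a limit, as compound 3 does, and the step from compound 3 to compound 4 cannot be read: the limit of > 100000 nM in this assay, at which 3 of the 4 values shown sit.

From the compounds shown here alone, whether thiophen-2-yl in place of phenyl on a carbon with a double bond to nitrogen lowers the number at all on the core of compound 3, as it does on the core of compound 1, stays open.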